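Dimethylamino for Chloro on a Shared Quinoline-Free Core

A few compounds are considered here, and "the series" means these few. Any claim that something is new, unique, unknown or untested is made for them only; others in the source may bear on it.

Measured so far:
Compound 1 `CCCCc1ccc(-c2ccc3ncc(-c4noc(C(F)(F)F)n4)cc3c2)cc1` in a functional assay on RD cells (Homo sapiens) for inhibition, read by luminescence and ATP content, with a stated time of 72 h (on this read-out higher numbers stand for lower toxicity in this test and lower numbers for higher toxicity in this test), gives > 7400 nM, a limit of the assay.
Compound 2 `FC(F)(F)c1nc(-c2cnc3ccc(-c4ccc(Cl)cc4)cc3c2)no1` gives > 200000 nM, likewise a limit.

Compound 2 therefore stands at a limit in this assay, not at a number. Going by the values given here, the only measured step, a step that the two limits leave unreadable from compound 1 to compound 2, is unreadable, since both ends are limits. Compound 3 `CN(C)c1ccc(-c2ccc3ncc(-c4noc(C(F)(F)F)n4)cc3c2)cc1` differs from compound 2 by dimethylamino in place of chloro on an aromatic carbon. Among the compounds with values here, no measured step reads on this change, so the expected step of an at least 1.3-fold lower number from compound 2 to compound 3 (0.12 log units; that floor lies within the scatter) is taken as none beyond the scatter. Compound 3 is estimated at 150000 nM, with a range from 30000 nM to 400000 nM, and a limit is again the most likely report.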

Compound 3, half-maximal cytotoxic concentration: > 22200 nM
Compound 3: only a limit was reported; the forecaster's own chance of this, stated with the estimate: 70%; the middle value is on the limit's open side.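

Compound 3, like compound 1 and compound 2, is reported only as a limit, so no new step can be read among them. The compounds shown leave open whether butyl, chloro and dimethylamino differ at all in this assay.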